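The compounds below may be only part of what the source reports. "The series", "measured", "known", "first", "only" and "open" are said of these compounds alone.

Three nucleoside-like compounds have been tested in an ADME assay on MRC5 cells (Homo sapiens), read by MTT assay, with a stated time of 72 h (a lower number here means a stronger inhibitor, a higher number a weaker inhibitor), and a fourth is still to be measured. Compound 1 `Cc1nc(N)c2c(-c3cccs3)cn([C@@H]3O[C@H](CO)[C@@H](O)[C@H]3O)c2n1` carries a thiophen-2-yl group on its fused core. Compound 3 `Cc1nc(N)c2c(-c3ccoc3)cn([C@@H]3O[C@H](CO)[C@@H](O)[C@H]3O)c2n1` shares that core but bears a furan-3-yl group in the same position. Compound 2 `CSc1ncnc2c1c(-c1ccoc1)cn2[C@@H]1O[C@H](CO)[C@@H](O)[C@H]1O` also carries a furan-3-yl group, yet on a different core, and the difference between the core of compound 2 and the core of compound 3 is not broken down here.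

In this assay compound 1 gives > 100000 nM, which is a limit of the assay and not a number. Compound 3 gives > 100000 nM, again only a limit. Compound 2 gives > 100000 nM, likewise a limit. Because all three values rest at the limit of > 100000 nM in this assay, at which 3 of the 3 values shown sit, the step that the two limits leave unreadable from compound 3 to compound 1 cannot be read, even though the change thiophen-2-yl in place of furan-3-yl on an aromatic carbon is clearly defined.

Within the data shown here, compound 4 `CSc1ncnc2c1c(-c1cccs1)cn2[C@@H]1O[C@H](CO)[C@@H](O)[C@H]1O` is derived from compound 2 by the change (thiophen-2-yl in place of furan-3-yl on an aromatic carbon), the same change at the same place as the one from compound 3 to compound 1. The expected step is a step that the limit leaves unreadable from compound 2 to compound 4, and this expectation rests on the fact that every measured value sits at the limit of > 100000 nM in this assay, at which 3 of the 3 values shown sit. Compound 4 is therefore expected to show roughly 200000 nM, most likely reported only as a limit again, within a range of about 100000 nM to 1000000 nM.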

Compound 4, half-maximal inhibitory concentration: > 100000 nM
Compound 4 gave a limit, no number (the forecaster's own chance of this, stated with the estimate: 90%); the middle value does not contradict the limit.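

Compound 4 gives only a limit and not a number, as compound 2 does, so no size can be read for the change from compound 2 to compound 4 or from compound 3 to compound 1, because all the values rest at one limit: the limit of > 100000 nM in this assay, at which 4 of the 4 values shown sit. The compounds shown leave open how strongly any of them acts in this assay, and whether thiophen-2-yl and furan-3-yl differ there at all.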